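Swapping a methoxy for a hydroxy on a pyrazole series

A few compounds are considered here, and "the series" means these few. Any claim that something is new, unique, unknown or untested is made for them only; others in the source may bear on it.

Compound 2 `COc1cc(C)cc(-c2nn(CC#N)cc2-c2ccnc(-c3ccc(N(C)C)cc3)c2)c1`: 96%
Compound 1 `Cc1cc(O)cc(-c2nn(CC#N)cc2-c2ccnc(-c3ccc(Oc4ccccc4)cc3)c2)c1`: 94%

Of the compounds shown here, two have been measured in a functional assay on SR cells (Homo sapiens) for cytotoxicity, read by sulforhodamine B assay, with a stated time of 48 h, tested at 0.001 uM; on this read-out lower numbers stand for a stronger effect and higher numbers for a weaker effect at the one concentration tested. Compound 2 gives 96% and stands highest of the two numbers, meaning the weakest effect at the single concentration used. Its nearest neighbour is compound 1, which gives 94%, a number that lies within the scatter of the method. Both numbers are close to the top of the scale, so neither compound does much to the cells under these conditions.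

The next compound, compound 3 `Cc1cc(O)cc(-c2nn(CC#N)cc2-c2ccnc(-c3ccc(N(C)C)cc3)c2)c1`, differs from compound 2 in one place: hydrogen in place of methyl on an oxygen on an aromatic ring. Put another way, the 3-methoxy-5-methylphenyl group of compound 2 becomes the 3-hydroxy-5-methylphenyl group also found in compound 1. Within the data shown here, no measured pair shows what this exact change does here. Since compound 1 already carries the hydroxy group and gives a number indistinguishable from compound 2, the step of a number 1 percentage points lower from compound 2 to compound 3 (within the scatter) is expected to stay within the scatter. Compound 3 is therefore estimated at 95%, within a range from 85% to 102%.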

Compound 3, a percentage reported as activity, at one concentration (the size of the read-out at that concentration, not a potency): 93%
For compound 3 the middle estimate is 2 percentage points above the measured one; measured number inside the range.
By their numbers in this assay, from the lowest: compounds 3, 1 and 2 (each within the scatter of the next).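

In this assay, among these compounds, hydrogen in place of methyl on an oxygen on an aromatic ring, which turns methoxy into hydroxy, gives a number 3 percentage points lower from compound 2 to compound 3 (within the scatter), so at the one concentration tested this change has no effect that can be told apart from the scatter. The other single change now available, dimethylamino in place of phenoxy on an aromatic carbon, gives a number 1 percentage points lower from compound 1 to compound 3 (within the scatter), so this second place in the molecule also shows no readable change under these conditions. Nothing measured alongside these compounds speaks to what lies behind this result.

All three numbers sit close to the top of the scale, so these compounds leave open whether either change would matter at a concentration where the cells respond more clearly. They also leave open whether the number would move with an ethyl group or a longer chain ending in an amine on that oxygen, or with a carboxylic acid in place of the hydroxy group.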